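The compounds below may be only part of what the source reports. "The series", "measured", "known", "first", "only" and "open" are said of these compounds alone.

For the measured compounds named here, in a functional assay on HUVEC cells (Homo sapiens) for inhibition, with a stated time of 4 days (a higher number here means a weaker inhibitor, a lower number a stronger inhibitor), three compounds have numbers so far. Compound 1 `COc1ccc(C#N)cc1COc1ccc(Cl)c(C)c1` gives 1500 nM, compound 2 `COc1ccc(C(N)=O)cc1/C=C/c1cccc(C#N)c1` gives 49000 nM, and compound 3 `COc1ccc(C(N)=O)cc1/C=C/c1ccccc1F` gives 2000 nM. Compound 3 therefore stands level with compound 1 within the usual scatter, while compound 2 has a much higher number, beyond the scatter from compound 3.

Compound 4 `COc1ccc(C(N)=O)cc1/C=C/c1ccccc1Cl` keeps the frame of compound 3 with a single swap: chloro in place of fluoro on an aromatic carbon, ortho to a large group (chloro in place of fluoro on an aromatic carbon). Going by the values given here, no measured pair here shows this swap directly, so the expectation rests on how small the change is: one halogen atom for another. The gap between compound 3 at 2000 nM and compound 2 at 49000 nM is a warning that substituents on this ring can matter, so the range should stay generous.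

The expected outcome is no shift beyond the scatter, with the estimated step being a 1.3-fold higher number from compound 3 to compound 4 (0.10 log units; within the scatter). The estimate for compound 4 is 2500 nM, with an expected range of 800 nM to 8000 nM.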

Compound 4, half-maximal inhibitory concentration: 23000 nM
Beside the measured number, compound 4's estimate is 9.2-fold (0.96 log units) below it; the whole stated range lies below it.
By their numbers in this assay, from the lowest: compounds 1 and 3 (each within the scatter of the next); then compound 4; then compound 2.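

In this assay, the place on the aromatic ring ortho to a large group proves highly sensitive: the swap of chloro in place of fluoro gives a 12-fold higher number from compound 3 to compound 4 (1.06 log units; beyond the scatter) even though one heavy atom simply replaces another and neither group has hydrogen-bond donors or acceptors. The earlier compounds shown here could only hint that this ring matters, whereas this pair shows that a single-atom change at this place can move the number well beyond the scatter, so fluoro and chloro cannot be treated as interchangeable here. Nothing available explains this large step.

On these data alone, it remains open where a hydroxyl group, an amine or a bare hydrogen at this place would fall relative to compound 3 and compound 4. As far as these compounds go, whether the same swap has a similar effect on another frame also remains open.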